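Working notes: chloro in place of trifluoromethyl

The source may hold more compounds than are shown below. What is called first, only, known or untested is meant among the compounds shown, and "the series" means these compounds.

Measured compounds:
compound 1 `COc1ccc(-c2c(Cl)c(=O)c3c(OC)cc(OC)cc3n2S(=O)(=O)c2ccc(OC)cc2)cc1`: 17900 nM
compound 2 `COC(=O)c1cc(=O)c2c(OC)cc(OC)cc2n1S(=O)(=O)c1ccc(C)cc1`: 9700 nM
compound 3 `COC(=O)c1cc(=O)c2cc(NC(=O)Nc3ccc(Cl)c(C(F)(F)F)c3)ccc2[nH]1`: > 12600 nM

In a functional assay on SUP-B15 cells (Homo sapiens) for antiproliferative activity, with a stated time of 72 h (on this read-out higher numbers stand for an effect only at larger amounts of compound and lower numbers for an effect already at smaller amounts), compound 1 gives 17900 nM and compound 2 gives 9700 nM. Compound 3 returns only a limit in this assay, > 12600 nM, so no number of its own is known for it. This is the limit of > 12600 nM in this assay, at which 1 of the 3 values shown sits. Compound 3 therefore stands at the weak end of the three entries, with the two real numbers belonging to compound 1 and compound 2.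

Compound 4 `COC(=O)c1cc(=O)c2cc(NC(=O)Nc3ccc(Cl)c(Cl)c3)ccc2[nH]1` is still to be measured in this assay. It differs from compound 3 by chloro in place of trifluoromethyl on an aromatic carbon. For the measured compounds named here, no step between two measured compounds is available, so nothing here shows how much such a change moves the read-out. The expectation for compound 4 rests on compound 3 alone because compound 3 gives > 12600 nM and the change is a small one on the outer ring. The step from compound 3 to compound 4 is expected to be a step that the limit leaves unreadable from compound 3 to compound 4, not beyond the scatter in either direction. Compound 4 is expected at 18000 nM, with a range from 6000 nM to 60000 nM, and a limit rather than a number is the likelier outcome.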

Compound 4, half-maximal effective concentration: 5520 nM
Estimate against measurement, compound 4: 3.3-fold (0.51 log units) above, outside the stated range (below it).
By their numbers in this assay, from the lowest: compounds 4, 2 and 1 (each within the scatter of the next, the first and the last beyond it).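

In this assay, this aromatic carbon, ortho to a chloro group, gives the series its first readable step: chloro in place of trifluoromethyl gives an at least 2.2-fold lower number from compound 3 to compound 4 (0.35 log units; beyond the scatter). The read-out therefore responds to a single change at this position, with 1 heavy atom entering where 4 leave, and compound 4 has a number of its own. Compound 3 has only a limit, and the step can be read only as a minimum because its starting point is that limit: the limit of > 12600 nM in this assay, at which 1 of the 4 values shown sits.

As far as these compounds go, whether a nitrile or an amine at the same carbon would lower the number further or raise it remains open, as does the effect of a carboxylic acid in place of the methyl ester on the shared core. The compounds shown give no measured property for chloro or trifluoromethyl, so the step remains without an explanation.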